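Trimming the allylic ester: from compound 3 to compound 4

A few compounds are considered here, and "the series" means these few. Any claim that something is new, unique, unknown or untested is made for them only; others in the source may bear on it.

Measured so far:
- compound 1, `COc1cc(/C=C/COC(C)=O)ccc1OC(C)=O`: 1060 nM
- compound 2, `CC[C@H](C)C(=O)Oc1ccc(/C=C/COC(C)=O)cc1OC`: 480 nM
- compound 3, `CCCC(=O)OC/C=C/c1ccc(OC(=O)CCC)c(OC)c1`: 17300 nM

All three were tested in a functional assay on U-87MG ATCC cells for antiproliferative activity against U-87 MG (Homo sapiens), read by sulforhodamine B assay, with a stated time of 72 h; on this read-out higher numbers stand for weaker inhibition and lower numbers for stronger inhibition. Among them compound 3 stands highest: compound 1 and compound 2 both give numbers far lower, and both gaps lie well beyond the scatter. Compound 4, `CCCC(=O)Oc1ccc(/C=C/COC(C)=O)cc1OC`, has not yet been measured. It differs from compound 3 in one place: hydrogen in place of ethyl on a saturated chain carbon bound to a carbonyl carbon. Cut one bond further out, the same change reads propylcarbonyl to acetyl at the allylic oxygen, while the ester on the phenol stays as propylcarbonyl.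

Among the measured compounds shown here, the only single-point step measured, a 2.2-fold lower number from compound 1 to compound 2 (0.34 log units; beyond the scatter), concerns the other ester, the one on the phenol, where a larger acyl group gave a modestly lower number. Compound 3 carries the larger acyl group on both oxygens yet sits far above compound 1, so the high number of compound 3 is most plausibly tied to the allylic ester. Returning that ester to acetyl should therefore bring compound 4 back toward compound 1 and compound 2, and compound 4 is expected to show a 25-fold lower number from compound 3 to compound 4 (1.39 log units; beyond the scatter). The estimate for compound 4 is 700 nM, within a range from 250 nM to 2500 nM.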

Compound 4, half-maximal inhibitory concentration: 10500 nM
Compound 4: the middle estimate sits 15-fold (1.18 log units) below what was measured; measured number outside the range, above it.
By their numbers in this assay, from the lowest: compound 2; then compound 1; then compounds 4 and 3 (each within the scatter of the next).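

In this assay, going from propylcarbonyl to acetyl on the allylic ester gives a 1.6-fold lower number from compound 3 to compound 4 (0.22 log units; within the scatter), so with propylcarbonyl on the phenol ester, this change at the allylic ester shows no clear effect. With acetyl held on the allylic ester, the large differences appear when the phenol ester changes: acetyl to propylcarbonyl gives a 9.9-fold higher number from compound 1 to compound 4 (1.00 log units; beyond the scatter), and the sec-butyl group to straight propyl gives a 22-fold higher number from compound 2 to compound 4 (1.34 log units; beyond the scatter). Acyl size alone does not set the order at the phenol ester, as compound 1 with acetyl and compound 2 with sec-butyl both have lower numbers than compound 4 with propylcarbonyl, and no independent measurement here explains this.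

The compounds shown leave open whether the allylic ester would matter as little alongside acetyl or sec-butyl on the phenol ester, since only the propylcarbonyl pair tests that change. They also leave open how a longer straight chain, an isopropyl or tert-butyl group, or a free hydroxyl in place of the phenol ester would compare.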